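Methoxy for nitro on the aryl ring of compound 3

The source may report more compounds than this note shows. Statements on the series, on what has been measured and on what is new or still open speak of the compounds shown alone.

Three compounds share one core and differ only in the group on the benzene ring. In a functional assay on SSMC-7721 cells (Homo sapiens) for antiproliferative activity, read by CCK-8 assay, with a stated time of 48 h (a lower number here means a stronger inhibitor, a higher number a weaker inhibitor), compound 1 `O=c1c2ccccc2[se]n1-c1nnc(-c2ccccc2Cl)s1` gives 40200 nM, compound 2 `O=c1c2ccccc2[se]n1-c1nnc(-c2ccccc2Br)s1` gives 27400 nM, and compound 3 `O=c1c2ccccc2[se]n1-c1nnc(-c2ccccc2[N+](=O)[O-])s1` gives 22500 nM, the lowest of the three numbers, though a 1.8-fold lower number from compound 1 to compound 3 (0.25 log units; within the scatter) and a 1.2-fold lower number from compound 2 to compound 3 (0.09 log units; within the scatter) both stay within the scatter, as does a 1.5-fold lower number from compound 1 to compound 2 (0.17 log units; within the scatter). Compound 4 `COc1ccccc1-c1nnc(-n2[se]c3ccccc3c2=O)s1` carries the change (methoxy in place of nitro on an aromatic carbon). Every measured exchange at that position left this assay essentially unchanged, so no step beyond the scatter is expected here either, in either direction; the expected shift is a 1.3-fold higher number from compound 3 to compound 4 (0.12 log units; within the scatter). Compound 4 is therefore estimated at 30000 nM, with a range from 13000 nM to 70000 nM.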

Compound 4, half-maximal inhibitory concentration: 14300 nM
Compound 4: the middle estimate sits 2.1-fold (0.32 log units) above what was measured, and the stated range covers the measured number.
By their numbers in this assay, from the lowest: compounds 4, 3, 2 and 1 (each within the scatter of the next, the first and the last beyond it).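

Methoxy gives the first exchange at this position to pass beyond the scatter in this assay (a 2.8-fold lower number from compound 1 to compound 4 (0.45 log units; beyond the scatter)), a modest step, whereas a 1.6-fold lower number from compound 3 to compound 4 (0.20 log units; within the scatter) and a 1.9-fold lower number from compound 2 to compound 4 (0.28 log units; within the scatter) both remain within it. The position is thus not wholly indifferent to its group, but only the exchange of chloro for methoxy shows this. No measurement here gives a reason for that step.

As far as these compounds go, whether an amine or a carboxylic acid at this place, on an aromatic carbon ortho to a large group, would move the number further remains open.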